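Compound 1 to compound 4: dropping the methoxy

The source may hold more compounds than are shown below. What is called first, only, known or untested is meant among the compounds shown, and "the series" means these compounds.

In a physicochemical assay for solubility, read by HPLC, in phosphate buffer, at pH 7.4 (a higher number here means a more soluble compound, a lower number a less soluble compound), compound 1 `COc1ccc(-c2ccnc(Nc3cccc(S(N)(=O)=O)c3)n2)cc1` gives 38400 nM, the higher of the two actual numbers in this small set. Compound 2 `COc1ccc(-c2ccnc(Nc3cccc(C(N)=O)c3)n2)cc1` gives 4100 nM. Compound 3 `COc1ccc(-c2ccnc(Nc3cccc(NS(C)(=O)=O)c3)n2)cc1` gives < 500 nM, which is a limit of the assay and not a number.

Compound 4 `NS(=O)(=O)c1cccc(Nc2nccc(-c3ccccc3)n2)c1` is still unmeasured. It has hydrogen in place of methoxy on an aromatic carbon, para to a large group, so that 4-methoxyphenyl becomes phenyl: hydrogen in place of methoxy on an aromatic carbon.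

The measured steps all change the sulfamoyl group and leave the methoxy untouched. These are the modest 9.4-fold lower number from compound 1 to compound 2 (0.97 log units; beyond the scatter), the large at least 76-fold lower number from compound 1 to compound 3 (1.88 log units; beyond the scatter) and the at least modest an at least 8.2-fold lower number from compound 2 to compound 3 (0.91 log units; beyond the scatter). None of them measures a change at the methoxy, so their sizes do not carry over to this step. The expectation therefore stays anchored on compound 1 at 38400 nM, with no shift beyond the scatter in this assay and no firm direction. The expected step is a 1.2-fold higher number from compound 1 to compound 4 (0.07 log units; within the scatter). For compound 4 the estimated value is 45000 nM, with an expected range of 15000 nM to 130000 nM.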

Compound 4, solubility: 3400 nM
Estimate against measurement, compound 4: 13-fold (1.12 log units) above; the measured number lies below the stated range.
By their numbers in this assay, from the lowest: compounds 4 and 2 (each within the scatter of the next); then compound 1. At a limit, below all of these: compound 3.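

In this assay, this position on the 4-methoxyphenyl group is not a silent one: hydrogen in place of methoxy gives an 11-fold lower number from compound 1 to compound 4 (1.05 log units; beyond the scatter). Within the data shown here, all the earlier steps changed the sulfamoyl group, so this is the first sign that the number for compound 1 also depends on the aromatic carbon para to a large group, with the sulfamoyl group left as it stands. Nothing shown here bears on the cause of this step.

With only methoxy and hydrogen shown at this position, it stays open whether a hydroxyl, a fluorine or a dimethylamino group there would sit nearer compound 1 or compound 4. From the compounds shown here alone, it also stays open whether the same change gives a step of similar size with the carbamoyl group of compound 2 in place of the sulfamoyl group.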